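This account rests on a few compounds, and the source may have more. Where it says the series, first, only, none or still open, it means among the compounds named here.

Measured compounds:

Compound 1, `O=C(CCl)N1CCCC(n2nc(-c3ccc(Oc4ccccc4)cc3)cc2CO)C1`, gives 400 nM in a functional assay on Rec1 cells (Homo sapiens) for inhibition, read by luminescence and CellTiter-Glo, with a stated time of 72 h; a higher number here means a weaker inhibitor, a lower number a stronger inhibitor.
Compound 2, `O=C(O)c1cc(-c2ccc(Oc3ccccc3)cc2)nn1C1CCCN(C(=O)CCl)C1`, gives 2200 nM.
Compound 3, `O=C(CCl)Nc1cccc(Cn2nc(-c3ccc(Oc4ccccc4)cc3)cc2CO)c1`, gives 400 nM.

Compound 1 and compound 3 share one value at the digits printed, within the scatter, so no order is drawn between them; the difference between their two cores is not broken down here. Against compound 2, the change carboxy in place of hydroxymethyl on an aromatic carbon produced a 5.5-fold higher number from compound 1 to compound 2 (0.74 log units; beyond the scatter).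

Compound 4, `O=C(CCl)Nc1cccc(Cn2nc(-c3ccc(Oc4ccccc4)cc3)cc2C(=O)O)c1`, is still to be measured. It differs from compound 3 by carboxy in place of hydroxymethyl on an aromatic carbon, the same kind of change as that from compound 1 to compound 2, though the place is described there as next to the ring atom that bears a 1-((chloromethyl)carbonyl)piperidin-3-yl group, and here as next to the ring atom that bears a large group. An expected step of a 5.5-fold higher number from compound 3 to compound 4 (0.74 log units; beyond the scatter) is taken, because of a 5.5-fold higher number from compound 1 to compound 2 (0.74 log units; beyond the scatter) on the other core. Compound 4 is therefore estimated at 2200 nM, expected between 1000 nM and 5000 nM.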

Compound 4, half-maximal inhibitory concentration: 7100 nM
The estimate for compound 4 lay 3.2-fold (0.51 log units) below the measured number, outside the stated range (above it).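

In this assay, carboxy in place of hydroxymethyl gives an 18-fold higher number from compound 3 to compound 4 (1.25 log units; beyond the scatter) on the second core, so the direction of the change carries over, and the hydroxymethyl compounds read lower on both cores. The size of the step does not carry over from one core to the other: the same change on two cores in this assay, a 5.5-fold higher number (0.74 log units; beyond the scatter) from compound 1 to compound 2 and an 18-fold higher number (1.25 log units; beyond the scatter) from compound 3 to compound 4, 3.2-fold (0.51 log units) apart, beyond the scatter of two such steps. Among the compounds shown here, two cores show only that a step taken from one core is a poor guide to the size on the other; they do not show what sets the difference, or how a third core would respond.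

Open, from the compounds shown here alone, is how a methyl ester or a primary amide would read at the same place. Also open, going by these compounds, is whether a longer chain carrying the hydroxyl would hold the level of the hydroxymethyl compounds.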